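The source may hold more compounds than are shown below. What is called first, only, known or untested is meant among the compounds shown, and "the series" means these compounds.

In a functional assay on HCT-116 cells (Homo sapiens) for cytotoxicity, read by sulforhodamine B assay, with a stated time of 48 h (on this read-out higher numbers stand for weaker inhibition and lower numbers for stronger inhibition), compound 1 `COc1ccc(C(=O)Nc2nn(C(=O)C3CC3)c3c2CN(C(=O)c2ccccc2)C3)cc1` gives 5180 nM while compound 2 `CC(=O)n1nc(NC(=O)c2ccccc2)c2c1CN(C(=O)c1cccc(F)c1)C2` gives 21900 nM as the higher of the two numbers, a gap beyond the scatter. Compound 3 `CC(=O)n1nc(NC(=O)c2ccccc2)c2c1CN(C(=O)CCl)C2` has not yet been measured. It differs from compound 2 by a single change (chloromethyl in place of 3-fluorophenyl on a carbonyl carbon) on a carbonyl carbon, with chloromethyl in place of 3-fluorophenyl. For the measured compounds named here, no measured pair shows this change alone, so the expectation is a loose one. A moderate step toward stronger inhibition in this assay is expected, beyond the scatter, resting on compound 2 standing at 21900 nM as the weaker of the pair and on compound 1 reaching 5180 nM in the same series. The estimated step is a 4.9-fold lower number from compound 2 to compound 3 (0.69 log units; beyond the scatter) on this reasoning. For compound 3 the expected value is 4500 nM within an estimated range of 900 nM to 20000 nM on this read-out.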

Compound 3, half-maximal inhibitory concentration: 4100 nM
Beside the measured number, compound 3's estimate is 1.1-fold (0.04 log units) above it; the measured number falls inside the stated range.
By their numbers in this assay, from the lowest: compounds 3 and 1 (each within the scatter of the next); then compound 2.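

In this assay, for the compounds shown here, chloromethyl in place of 3-fluorophenyl on a carbonyl carbon whose other neighbour is an amide-type nitrogen in a ring gives a 5.3-fold lower number from compound 2 to compound 3 (0.73 log units; beyond the scatter), the first change at a single place that can be read. At this position, therefore, an aromatic ring is not needed to reach the lower number, and removing it moves the reading toward stronger inhibition rather than losing it. Nothing shown here accounts for the size or direction of this step.

As far as these compounds go, it remains open whether the chlorine matters to the step, which a plain methyl, a longer chain such as chloroethyl, or an amine such as dimethylaminomethyl on the same carbonyl carbon would help to settle. From the compounds shown here alone, it is also open whether the same change gives a similar step on the core of compound 1.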